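The source may hold more compounds than are shown below. What is called first, only, known or untested is meant among the compounds shown, and "the series" means these compounds.

Measured compounds and their numbers in a physicochemical assay for solubility, read by spectrophotometry, in phosphate buffer, with a stated time of 2 h, at pH 7.4; a higher number here means a more soluble compound, a lower number a less soluble compound:

compound 1, `COc1ccc2[nH]c(C(=O)N3CC(=O)N(Cc4ccccc4)[C@@H](CCc4ccccc4)C3)cc2c1`, gives 4400 nM
compound 2, `COc1ccc2[nH]c(C(=O)N3CC(=O)N(Cc4ccccc4)[C@@H](N4[C@H](C)CCC[C@@H]4C)C3)cc2c1`, gives 100000 nM
compound 3, `COc1ccc2[nH]c(C(=O)N3CC(=O)N(Cc4ccccc4)[C@@H](CN4CCC(C(C)C)CC4)C3)cc2c1`, gives 12000 nM

Compound 3 stands second highest of the three in this assay: it lies above compound 1, with a 2.7-fold higher number from compound 1 to compound 3 (0.44 log units; beyond the scatter), and below compound 2, with an 8.3-fold lower number from compound 2 to compound 3 (0.92 log units; beyond the scatter). Compound 4 is `COc1ccc2[nH]c(C(=O)N3CC(=O)N(Cc4ccccc4)[C@@H](CN4CCn5cccc5C4)C3)cc2c1`, not yet measured. It differs from compound 3 in one place: a group of 9 heavy atoms (7 carbon, 2 nitrogen; one five-membered aromatic ring with 1 hetero atom, one six-membered non-aromatic ring with 2 hetero atoms) in place of a group of 9 heavy atoms (8 carbon, 1 nitrogen; one six-membered non-aromatic ring with 1 hetero atom), on a saturated chain carbon bound to a saturated ring carbon.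

Going by the values given here, none of the measured steps changes exactly this group. Among the compounds with values here, the step that comes nearest is the one into compound 3 itself, a 2.7-fold higher number from compound 1 to compound 3 (0.44 log units; beyond the scatter), where a benzyl was replaced by the 4-isopropylpiperidin-1-yl group on the same saturated chain carbon; the other step, an 8.3-fold lower number from compound 2 to compound 3 (0.92 log units; beyond the scatter), exchanges a whole ring substituent on a saturated ring carbon and is further removed. Both steps were modest in size. Within the data shown here, with no direct precedent for the new group and both neighbouring steps modest, the step of a 1.3-fold higher number from compound 3 to compound 4 (0.10 log units; within the scatter) is expected to be small, if anything a slight rise. Compound 4 is therefore estimated at 15000 nM, with a range from 5000 nM to 45000 nM.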

Compound 4, solubility: 29700 nM
Compound 4: the middle estimate sits 2.0-fold (0.30 log units) below what was measured; the measured number falls inside the stated range.
By their numbers in this assay, from the lowest: compound 1; then compound 3; then compound 4; then compound 2.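

In (this assay), the group with a five-membered aromatic ring and a six-membered non-aromatic ring with 2 hetero atoms, placed on the saturated chain carbon bound to a saturated ring carbon, gives a step beyond the scatter when it replaces 4-isopropylpiperidin-1-yl (a 2.5-fold higher number from compound 3 to compound 4 (0.39 log units; beyond the scatter)), so two groups of equal heavy-atom count can still differ at this place. Measured against the benzyl that stands at the same place in compound 1, the new group gives a larger step (a 6.8-fold higher number from compound 1 to compound 4 (0.83 log units; beyond the scatter)), yet the number stays under that of the compound with 2,6-dimethylpiperidin-1-yl on the saturated ring carbon (a 3.4-fold lower number from compound 2 to compound 4 (0.53 log units; beyond the scatter)), which remains the highest of the four. The data presented hold nothing that bears on what lies behind these differences.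

The compounds shown leave open whether the rise follows the five-membered aromatic ring or the second ring nitrogen, and a morpholin-4-yl or a piperazin-1-yl on the same saturated chain carbon would help to tell these apart. Also open, on these data alone, is how the new group would behave directly on the saturated ring carbon.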